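Taking Away One Methyl Group: From Compound 1 to Compound 3

The source may hold more compounds than are shown below. What is called first, only, known or untested is meant among the compounds shown, and "the series" means these compounds.

Measured so far in an assay on HEK293 cells for inhibition of N-acylethanolamine-hydrolyzing acid amidase (Rattus norvegicus), read by LC-MS, with a stated time of 30 min; on this read-out higher numbers stand for weaker inhibition and lower numbers for stronger inhibition:
compound 1, `Cc1ccc(CCCCCC(=O)N2CCOC2=O)cc1C`, gives only a limit of the assay, > 20000 nM.
compound 2, `NC(=O)c1ccc(CCCCCC(=O)N2CCOC2=O)cc1`, gives only a limit of the assay, > 20000 nM.

Neither compound therefore has a number in this assay, and no order between compound 1 and compound 2 can be read from these results. Compound 1 stands at the limit of > 20000 nM in this assay, at which 2 of the 2 values shown sit.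

Compound 3, `Cc1cccc(CCCCCC(=O)N2CCOC2=O)c1`, is the next compound. Compared with compound 1 it shows (hydrogen in place of methyl on an aromatic carbon). Among the measured compounds shown here, no step between measured compounds is available to show what such a change does in this assay, so its size has to be guessed. The step that the limit leaves unreadable from compound 1 to compound 3 is expected to be none beyond the usual scatter. Compound 3 is accordingly expected to give 30000 nM, in a range from 8000 nM to 100000 nM, and most probably the assay will again report only a limit for compound 3 rather than a number.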

Compound 3, half-maximal inhibitory concentration: 350 nM
Beside the measured number, compound 3's estimate is 86-fold (1.93 log units) above it; the whole stated range lies above it.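

In this assay, hydrogen in place of the methyl group that sits ortho to the other methyl group and para to the large group gives an at least 57-fold lower number from compound 1 to compound 3 (1.75 log units; beyond the scatter), a step well beyond the scatter. Among the compounds shown here, this single position therefore decides whether the core of compound 1 gives a number at all, which the earlier compounds could not show, and a methyl group there goes with the loss of any readable inhibition. Going by these compounds, the true size of the step remains unknown, as compound 1 gives only a limit: the limit of > 20000 nM in this assay, at which 2 of the 3 values shown sit.

The compounds shown leave open what the remaining methyl group contributes, and why the one removed has so large an effect. On these data alone, it is also open how a chlorine atom or a methoxy group at the position now carrying hydrogen would compare, or how a longer chain would alter the number of compound 3.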